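Hydroxy in place of methoxy on an amine-bearing core

The source may report more compounds than this note shows. Statements on the series, on what has been measured and on what is new or still open speak of the compounds shown alone.

Compound 1, `COc1ccc(NC(=O)C2c3ccccc3CCN2C(=O)c2ccc(Cl)cc2)cc1`, in a functional assay on NUGC-3 cells (Homo sapiens) for inhibition, read by sulforhodamine B assay, with a stated time of 48 h (on this read-out higher numbers stand for weaker inhibition of growth and lower numbers for stronger inhibition of growth), gives 3630 nM.
Compound 2, `COc1ccc(NC(=O)C2NCCc3ccccc32)cc1`, in this assay is reported only as the limit > 10000 nM.

Compound 2 stands at the limit of > 10000 nM in this assay, at which 1 of the 2 values shown sits, so only a limit and no number is known for it, and the step of an at least 2.7-fold higher number from compound 1 to compound 2 (0.44 log units; beyond the scatter) runs into that limit. Compound 3, `O=C(Nc1ccc(O)cc1)C1NCCc2ccccc21`, differs from compound 2 by hydrogen in place of methyl on an oxygen on an aromatic ring. Among the measured compounds shown here, no measured step touches this oxygen, so the data give no direction for it. The step that the limit leaves unreadable from compound 2 to compound 3 is therefore expected to be small, with compound 3 likely again at the limit. Compound 3 is estimated at 15000 nM, in a range from 4000 nM to 60000 nM.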

Compound 3, concentration for 50% growth inhibition: 4370 nM
Compound 3: middle estimate off by 3.4-fold (0.54 log units), on the high side, within the range that was stated.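

Methoxy to hydroxy on the aromatic ring gives an at least 2.2-fold lower number from compound 2 to compound 3 (0.35 log units; beyond the scatter) in this assay, so this oxygen does matter when the ring amine nitrogen carries only hydrogen. Among the compounds shown here, this is the first measured step at this oxygen, and it gives a compound without the (4-chlorophenyl)carbonyl a measured number rather than a limit. The exact size of the step stays unknown, as one end of it is only a limit: the limit of > 10000 nM in this assay, at which 1 of the 3 values shown sits.

From the compounds shown here alone, whether the change holds with the (4-chlorophenyl)carbonyl on the ring nitrogen remains open. So does the effect of an amine or a fluorine in place of the hydroxy.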